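Removing a Methyl from Compound 1's Aromatic Methoxy

A few compounds are considered here, and "the series" means these few. Any claim that something is new, unique, unknown or untested is made for them only; others in the source may bear on it.

Of the compounds shown here, three that share a trimethoxyphenyl core have been measured in a functional assay on MGC-803 cells (Homo sapiens) for inhibition, read by MTT assay, with a stated time of 48 h; a lower number here means a stronger inhibitor, a higher number a weaker inhibitor. Compound 1, with structure `C/C=C/C(=O)N(Cc1ccc(OC)c(OC)c1)c1cc(OC)c(OC)c(OC)c1`, gives 20100 nM. Compound 3, with structure `COc1ccc(CNc2cc(OC)c(OC)c(OC)c2)cc1F`, gives 39700 nM, a number that sits within the usual scatter of compound 1's result, so the two cannot be told apart. Compound 2, with structure `COc1cc(NCc2cccc(O)c2)cc(OC)c1OC`, gives 57600 nM, which lies beyond the scatter from compound 1.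

Compound 4, with structure `C/C=C/C(=O)N(Cc1ccc(OC)c(O)c1)c1cc(OC)c(OC)c(OC)c1`, has not yet been measured. It differs from compound 1 in one place:

hydrogen in place of methyl on an oxygen on an aromatic ring

Among the measured compounds shown here, no measured pair shows the effect of this change on its own, so there is no direct guide. The three measured values all lie in the same broad region, and a change of a single carbon on an oxygen gives no clear reason to expect a move beyond the scatter in either direction. Compound 4 is therefore expected to land close to compound 1, giving an estimated 20000 nM, within a range from 8000 nM to 50000 nM, an expected step of a 1.0-fold lower number from compound 1 to compound 4 (0.00 log units; within the scatter).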

Compound 4, half-maximal inhibitory concentration: 27 nM
The estimate for compound 4 lay 740-fold (2.87 log units) above the measured number; the measured number lies below the stated range.
By their numbers in this assay, from the lowest: compound 4; then compounds 1, 3 and 2 (each within the scatter of the next, the first and the last beyond it).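

In this assay, replacing a methoxy with a hydroxy gives a 740-fold lower number from compound 1 to compound 4 (2.87 log units; beyond the scatter), a large step for the loss of one carbon. The two compounds differ only in this methyl on an oxygen on an aromatic ring, so this one place has a very large effect on the number in this series. Nothing among the data shown accounts for the size of this step.

It remains open whether the hydroxy itself matters or only the absence of the methyl, since the compounds shown carry neither an ethoxy group nor an amine at this place. They also leave open whether the same swap at any other methoxy group of compound 1 would give a step of similar size.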